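Moving the ethoxy group around the aryl amine

A few compounds are considered here, and "the series" means these few. Any claim that something is new, unique, unknown or untested is made for them only; others in the source may bear on it.

Of the compounds shown here, three of one shared core have been tested in a functional assay on MCF7 cells (Homo sapiens) for inhibition, read by sulforhodamine B assay; on this read-out higher numbers stand for weaker inhibition and lower numbers for stronger inhibition. Compound 1 `O=C1C=C(Nc2ccc(I)cc2)C(=O)c2c1nc1n2[C@H]2OC[C@@H](O)[C@H]2OC1` carries a 4-iodophenyl on the amine nitrogen, and in this assay compound 1 gives 2230 nM. Compound 2 `COc1cccc(NC2=CC(=O)c3nc4n(c3C2=O)[C@H]2OC[C@@H](O)[C@H]2OC4)c1` carries a 3-methoxyphenyl there; for compound 2 this assay reports only the limit > 4000 nM, not a number. Compound 3 `CCOc1ccccc1NC1=CC(=O)c2nc3n(c2C1=O)[C@H]1OC[C@@H](O)[C@H]1OC3` carries a 2-ethoxyphenyl; for compound 3 this assay likewise reports only the limit > 4000 nM. Compound 3 therefore stands at the weak end of what is known, together with compound 2, as the limit of > 4000 nM in this assay, at which 2 of the 3 values shown sit, shows. The step of an at least 1.7-fold higher number from compound 1 to compound 3 (0.25 log units; that floor lies within the scatter) is an at least, and the step that the two limits leave unreadable from compound 2 to compound 3.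

Compound 4 `CCOc1ccc(NC2=CC(=O)c3nc4n(c3C2=O)[C@H]2OC[C@@H](O)[C@H]2OC4)cc1` differs from compound 3 in one place: 4-ethoxyphenyl in place of 2-ethoxyphenyl on an amine nitrogen. The relevant measured steps are few. From compound 1 to compound 3 the number rose at least to the limit, and from compound 2 to compound 3 nothing readable emerges. Compound 1, whose 4-iodophenyl sits at the same place, gives 2230 nM. A number close to that is expected for compound 4, and the expected step of an at least 1.1-fold lower number from compound 3 to compound 4 (0.05 log units; that floor lies within the scatter) is small. Compound 4 is expected to give about 3500 nM, between 1500 nM and 9000 nM.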

Compound 4, half-maximal inhibitory concentration: 1430 nM
Beside the measured number, compound 4's estimate is 2.4-fold (0.39 log units) above it, outside the stated range (below it).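

In this assay, moving the ethoxy group from the 2-ethoxyphenyl to the 4-ethoxyphenyl on the amine nitrogen gives an at least 2.7-fold lower number from compound 3 to compound 4 (0.44 log units; beyond the scatter), the first step shown here to lie beyond the scatter, so with the same atoms joined differently, the place of the ethoxy group on the phenyl matters in this assay. The 4-ethoxyphenyl also stands apart from the 3-methoxyphenyl, with an at least 2.7-fold lower number from compound 2 to compound 4 (0.44 log units; beyond the scatter), although that change alters the chain as well as its place. Ethoxy in place of iodo on an aromatic carbon gives a 1.6-fold lower number from compound 1 to compound 4 (0.19 log units; within the scatter), which lies within the scatter, so compound 1 and compound 4 cannot be told apart here.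

Compound 2 and compound 3 both remain limits, so the step between them cannot be read: the limit of > 4000 nM in this assay, at which 2 of the 4 values shown sit. Going by these compounds, it remains open how a 3-ethoxyphenyl would compare, which would separate the place of the group from the length of its chain, and whether an amine, a carboxylic acid or a longer chain such as butoxy at the place of the ethoxy in compound 4 would move the number at all.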